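A Nitrooxy Group Enters the Side Ester of Compound 2

This account rests on a few compounds, and the source may have more. Where it says the series, first, only, none or still open, it means among the compounds named here.

Measured so far in an ADME assay on a cell-free system (plasma, Homo sapiens) for metabolic stability, with Plasma (Rattus norvegicus) as the target, read by HPLC, at pH 7.4; on this read-out higher numbers stand for a longer-lived compound and lower numbers for a shorter-lived compound:
Compound 1 `CC(=O)Oc1ccccc1C(=O)O[C@H]1CO[C@H]2[C@@H]1OC[C@H]2OC(=O)C1CC1` gives 0.015 h.
Compound 2 `CC(=O)Oc1ccccc1C(=O)O[C@H]1CO[C@H]2[C@@H]1OC[C@H]2OC(=O)c1cccc(C)c1` gives 0.0203 h.
Compound 3 `CC(=O)Oc1ccccc1C(=O)O[C@H]1CO[C@H]2[C@@H]1OC[C@H]2OC(=O)c1ccccc1OC(=O)c1ccccc1` gives 0.0722 h.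

Among these three numbers compound 2 stands second highest. Its nearest neighbour is compound 1, whose number lies within the scatter of the number of compound 2; compound 3 gives the highest number, and its gap to compound 2 lies beyond the scatter. Going by the values given here, the only step between two compounds that differ in a single place is a 1.4-fold higher number from compound 1 to compound 2 (0.13 log units; within the scatter).

Compound 4 `CC(=O)Oc1ccccc1C(=O)O[C@H]1CO[C@H]2[C@@H]1OC[C@H]2OC(=O)c1cccc(CO[N+](=O)[O-])c1` has not yet been measured in this assay. It differs from compound 2 in one place: nitrooxy in place of hydrogen on a saturated chain carbon bound to an aromatic carbon. The 3-methylphenyl ester of compound 2 is kept, and the nitrooxy group sits on its methyl carbon.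

Among the compounds with values here, no measured step bears directly on this change. Within the data shown here, the single step available, a 1.4-fold higher number from compound 1 to compound 2 (0.13 log units; within the scatter), exchanges a whole acyl group and still lies within the scatter, so it gives no ground for expecting a large movement. Compound 3 carries a larger acyl group and gives a higher number, but no single-place difference connects it to compound 4.

The expected step, a 1.0-fold lower number from compound 2 to compound 4 (0.01 log units; within the scatter), is therefore none beyond the scatter. Compound 4 is estimated at 0.02 h, with a range from 0.008 h to 0.05 h.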

Compound 4, half-life: 0.045 h
Estimate against measurement, compound 4: 2.3-fold (0.35 log units) below, within the range that was stated.
By their numbers in this assay, from the lowest: compounds 1 and 2 (each within the scatter of the next); then compounds 4 and 3 (each within the scatter of the next).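

In this assay, going by these compounds alone, nitrooxy in place of hydrogen on a saturated chain carbon bound to an aromatic carbon gives a 2.2-fold higher number from compound 2 to compound 4 (0.35 log units; beyond the scatter) and so is the first single-place change here that moves the number beyond the scatter, though only modestly. Exchanging cyclopropyl on a carbonyl carbon for 3-methylphenyl gave a 1.4-fold higher number from compound 1 to compound 2 (0.13 log units; within the scatter) and stayed within the scatter, while exchanging it for 3-((nitrooxy)methyl)phenyl gives a 3.0-fold higher number from compound 1 to compound 4 (0.48 log units; beyond the scatter) and goes beyond it, so among these acyl groups only the one bearing nitrooxy separates from the cyclopropyl ester. No measurement given here explains why the half-life changes with this group.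

On these data alone, whether a hydroxyl group or an amine on the same saturated chain carbon would shift the number as nitrooxy does stays open, as does the effect of a longer chain carrying the nitrooxy group. As far as these compounds go, it is also open whether a step of this kind belongs only to the 3-methylphenyl ester or would appear again when nitrooxy is placed on a different acyl group.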